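The compounds below may be only part of what the source reports. "The series", "measured", "known", "first", "only" and "open" are said of these compounds alone.

Compound 1 `CC(Sc1nnc(-c2ccncc2)s1)C(=O)Nc1ccccc1`: > 50000 nM
Compound 2 `CC(Sc1nnc(-c2ccncc2)s1)C(=O)NCc1ccc(Cl)cc1`: "not determined" (no result reported)
Compound 3 `CC(Sc1nnc(-c2ccncc2)s1)C(=O)Nc1ccccc1Cl`: > 50000 nM

In an ADME assay on BHK-21 cells (Mesocricetus auratus) for cytotoxicity, with a stated time of 3 days (on this read-out higher numbers stand for lower toxicity in this test and lower numbers for higher toxicity in this test), compound 1 gives > 50000 nM, which is a limit of the assay. In this assay compound 3 likewise gives > 50000 nM, again a limit. For compound 2 no result was reported in this assay. Compound 3 therefore stands at the limit, alongside one companion at the same limit and one entry without a number; this is summed up as the limit of > 50000 nM in this assay, at which 2 of the 3 values shown sit. Among the measured compounds shown here, the only step between measured compounds, a step that the two limits leave unreadable from compound 1 to compound 3, is unreadable: both of its ends are limits.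

Compound 4 `O=C(CSc1nnc(-c2ccncc2)s1)Nc1ccccc1Cl` differs from compound 3 by hydrogen in place of methyl on a saturated chain carbon bound to a carbonyl carbon and a sulfur. For the measured compounds named here, no measured step touches this change, and the one measured step, a step that the two limits leave unreadable from compound 1 to compound 3, gives no size at all, so nothing beyond the scatter is expected from the change in this assay. Compound 4 is therefore expected to remain at the limit, with an estimated 60000 nM and a range from 20000 nM to 200000 nM. The expected step that the limit leaves unreadable from compound 3 to compound 4 is meant to say no change beyond the scatter.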

Compound 4, half-maximal cytotoxic concentration: > 50000 nM
Compound 4: no number, only a limit (the forecaster's own chance of this, stated with the estimate: 85%); the middle value does not contradict the limit.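

Compound 3 and compound 4 both sit at a limit in this assay, so no size can be read for the step between them: the limit of > 50000 nM in this assay, at which 3 of the 4 values shown sit.

The compounds shown leave open whether hydrogen in place of methyl changes toxicity in this test at all, and at what concentration any of them becomes toxic to these cells.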